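Ring stereocentre flip from compound 2 to compound 4

The source may hold more compounds than are shown below. What is called first, only, known or untested is meant among the compounds shown, and "the series" means these compounds.

- compound 1 `O=C(O)[C@@H](CO)NC(=O)[C@H]1C[C@@H](O)CN1` gives 24000 nM 
- compound 2 `O=C(N[C@H](CO)C(=O)O)[C@@H]1C[C@H](O)CN1` gives 22200 nM 
- compound 3 `O=C(O)[C@H](CO)NC(=O)[C@@H]1C[C@H](O)CN1` gives 1050 nM 

In an ADME assay on the whole organism (Mus musculus, strain C57BL/6) for pharmacokinetics, read by HPLC, with a stated time of 6 h, at a dose of 25 mg/kg by the oral route (a lower number here means less compound in the circulation, a higher number more compound in the circulation at the dose given), compound 2 gives 22200 nM and sits level with compound 1, with compound 3 far lower. The next compound is compound 4 `O=C(N[C@H](CO)C(=O)O)[C@@H]1C[C@@H](O)CN1` and its change is small: the two compounds have the same atoms and bonds and differ only in configuration as drawn: 1 of 3 stereo elements differ; a stereocentre at a saturated ring carbon is drawn S in compound 2 and R in compound 4 and so a stereocentre at a saturated ring carbon is drawn S in compound 2 and R in compound 4.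

The closest guide is a 1.1-fold lower number from compound 1 to compound 2 (0.03 log units; within the scatter) where two ring stereocentres differ and the number stays within the scatter. The large steps of a 21-fold lower number from compound 2 to compound 3 (1.33 log units; beyond the scatter) and a 23-fold lower number from compound 1 to compound 3 (1.36 log units; beyond the scatter) both include the saturated chain carbon, and compound 4 keeps that centre as drawn in compound 2. No step beyond the scatter is therefore expected in this assay for this single ring change. The estimate is a 1.1-fold lower number from compound 2 to compound 4 (0.05 log units; within the scatter) as the expected outcome. Compound 4 is estimated at 20000 nM with an expected range from 6000 nM to 42000 nM at its two ends.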

Compound 4, maximal plasma concentration: 640 nM
Compound 4: the middle estimate sits 31-fold (1.49 log units) above what was measured; measured number below the stated range.
By their numbers in this assay, from the lowest: compounds 4 and 3 (each within the scatter of the next); then compounds 2 and 1 (each within the scatter of the next).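

In this assay, a single ring stereocentre can shift the number as strongly as the chain stereocentre did: inverting one gives a 35-fold lower number from compound 2 to compound 4 (1.54 log units; beyond the scatter), and inverting the other gives a 38-fold lower number from compound 1 to compound 4 (1.57 log units; beyond the scatter). Inverting both ring stereocentres together had left the number within the scatter, so the effect of one ring centre depends on how the other is drawn, at least across compounds 1, 2 and 4. Compound 4 also sits level with compound 3, with a 1.6-fold lower number from compound 3 to compound 4 (0.22 log units; within the scatter), although these two differ at both a chain and a ring stereocentre.

Still open, from the compounds shown here alone, is how the number would respond if an amine replaced the ring hydroxyl or a methyl ester replaced the carboxylic acid. Going by these compounds, it is also open whether the low numbers reflect less uptake from the gut or faster loss from the blood, and a peak concentration alone does not separate the two.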